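Taking the bromo off compound 2

A few compounds are considered here, and "the series" means these few. Any claim that something is new, unique, unknown or untested is made for them only; others in the source may bear on it.

Of the compounds shown here, three have numbers so far: compound 1 (`COc1cc(OC)c2sc(-c3ccc(N/C=C\C(=O)c4ccc(OC)c([N+](=O)[O-])c4)c(C)c3)nc2c1`), compound 2 (`COc1cc(OC)c2sc(-c3ccc(N/C=C\C(=O)c4cc(OC)c(OC)c(OC)c4Br)c(C)c3)nc2c1`) and compound 3 (`COc1ccc2nc(-c3ccc(N/C=C\C(=O)c4ccc(OC)c([N+](=O)[O-])c4)cc3)sc2c1`). In a functional assay on HeLa cells (Homo sapiens) for antiproliferative activity, read by sulforhodamine B assay, with a stated time of 48 h (a higher number here means a weaker inhibitor, a lower number a stronger inhibitor), compound 1 gives 9390 nM as its value, compound 2 gives 14700 nM as its value and compound 3 gives 17600 nM as its value. Compound 2 stands within the usual scatter of both of the others, so these numbers do not set it apart from either.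

Compound 4 (`COc1cc(OC)c2sc(-c3ccc(N/C=C\C(=O)c4cc(OC)c(OC)c(OC)c4)c(C)c3)nc2c1`) is compound 2 with hydrogen in place of bromo on an aromatic carbon. Among the compounds with values here, no measured pair of compounds shows this change on its own, so the data give no direct guide to its size. The expectation starts from compound 2 at 14700 nM and is for a modest move toward a stronger inhibitor, though a result within the scatter would be no surprise. This estimate means a 2.5-fold lower number from compound 2 to compound 4 (0.39 log units; beyond the scatter) as the expected step. Compound 4 is expected at 6000 nM with 1000 nM to 25000 nM as the estimated range.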

Compound 4, half-maximal inhibitory concentration: 16400 nM
Estimate against measurement, compound 4: 2.7-fold (0.44 log units) below; the measured number falls inside the stated range.
By their numbers in this assay, from the lowest: compounds 1, 2, 4 and 3 (each within the scatter of the next).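

In this assay the first direct test of this position gives a 1.1-fold higher number from compound 2 to compound 4 (0.05 log units; within the scatter) and so shows that bromo and hydrogen on this aromatic carbon cannot be told apart by this measurement. The group on the carbonyl carbon also gets its first direct comparison, which gives a 1.7-fold higher number from compound 1 to compound 4 (0.24 log units; within the scatter) and leaves 3,4,5-trimethoxyphenyl and 4-methoxy-3-nitrophenyl equally hard to tell apart on this core. Nothing available bears on the reason for either result.

Only bromo and hydrogen are shown on this carbon, so it remains open whether an amine or a carboxylic acid there would move the number beyond the scatter. From the compounds shown here alone, it also remains open whether either swap would behave the same way on the core of compound 3.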